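The source may report more compounds than this note shows. Statements on the series, on what has been measured and on what is new or still open speak of the compounds shown alone.

In a functional assay on HeLa cells (Homo sapiens) for antiproliferative activity, read by resazurin assay (on this read-out lower numbers stand for stronger inhibition and higher numbers for weaker inhibition), compound 1 `CCSC(=S)SCC(=O)c1ccccc1` gives 5010 nM, compound 2 `CCSC(=S)SCC(=O)c1ccc(C)cc1` gives 3980 nM, and compound 3 `Cc1ccc(C(=O)CSC(=S)SC(C)C)cc1` gives 25100 nM.

Compound 4 `CCSC(=S)SC(C)C(=O)c1ccccc1` has not yet been measured. It differs from compound 1 by methyl in place of hydrogen on a saturated chain carbon bound to a carbonyl carbon and a sulfur. The same kind of change has been seen once already, from compound 2 to compound 3, as methyl in place of hydrogen on a saturated chain carbon bound to a saturated chain carbon and a sulfur, and there it made a 6.3-fold higher number from compound 2 to compound 3 (0.80 log units; beyond the scatter). The two cores differ by hydrogen in place of methyl on an aromatic carbon, a difference that gave a 1.3-fold lower number from compound 1 to compound 2 (0.10 log units; within the scatter). The places are not the same, though: in compound 3 the methyl sits on a saturated chain carbon bound to a saturated chain carbon and a sulfur, in compound 4 on one bound to a carbonyl carbon and a sulfur. On this basis a step of a 4.0-fold higher number from compound 1 to compound 4 (0.60 log units; beyond the scatter) is expected for compound 4, somewhat smaller than the earlier one, the expectation resting on compound 1 at 5010 nM. Compound 4 is estimated at 20000 nM. Its expected range for compound 4 runs from 8000 nM to 60000 nM.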

Compound 4, half-maximal inhibitory concentration: 5010 nM
Compound 4: the middle estimate sits 4.0-fold (0.60 log units) above what was measured; the whole stated range lies above it.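

In this assay, methyl in place of hydrogen on a saturated chain carbon bound to a carbonyl carbon and a sulfur gives no change at the digits printed from compound 1 to compound 4 (within the scatter). Set beside the earlier methyl step, this shows that the size of that step did not carry from one core to the other: the same change on two cores in this assay, a 6.3-fold higher number (0.80 log units; beyond the scatter) from compound 2 to compound 3 and no change at the digits printed (within the scatter) from compound 1 to compound 4, 6.3-fold (0.80 log units) apart, beyond the scatter of two such steps It does not show whether the gap follows the carbon that carries the methyl or the rest of the core, as the two steps differ in both and there is only one step of each kind.

The compounds shown leave open what the same methyl would do on this carbon in the core of compound 2. They also leave open how an amine or a longer chain would behave there.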